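Chloro substitution on the hydrazone aryl of compound 1

The source may report more compounds than this note shows. Statements on the series, on what has been measured and on what is new or still open speak of the compounds shown alone.

Compound 1 `COc1ccc(OC)c(/C=C/C(=O)N/N=C/c2ccccc2)c1` is the parent of this pair, but for it the entry in a functional assay on DU-145 cells (Homo sapiens) for antiproliferative activity, read by sulforhodamine B assay, with a stated time of 48 h (on this read-out lower numbers stand for stronger inhibition of growth and higher numbers for weaker inhibition of growth), reads "not determined" (no result reported), so it offers no anchor on the read-out. Among the measured compounds shown here, the only measured relative is compound 2 `COc1ccc(OC)c(/C=C/c2nnc(Nc3ccc(Cl)cc3)o2)c1`, which shares the dimethoxystyryl part but carries a different linking unit; in this assay compound 2 gives 11400 nM, a weak result. Compound 3 `COc1ccc(OC)c(/C=C/C(=O)N/N=C/c2ccc(Cl)cc2)c1` is the target of the step. It differs from compound 1 by chloro in place of hydrogen on an aromatic carbon. With no measured step of this kind in the set, the change is expected to move growth inhibition little, in either direction, and quite possibly not beyond the usual scatter. Drawing on compound 2 as the sole measured point of the series, compound 3 is estimated to inhibit growth of these cells at about 15000 nM, with a plausible range from 3000 nM to 60000 nM.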

Compound 3, concentration for 50% growth inhibition: 217 nM
Compound 3: middle estimate off by 69-fold (1.84 log units), on the high side; measured number outside the range, below it.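

In this assay, among the compounds shown here, compound 1 offers no number to set against compound 3, so no step between them can be read. The compounds shown leave open how far chloro in place of hydrogen shifts growth inhibition. No supporting evidence bears on this result.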